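Working notes: compound 1 to compound 4, cytotoxicity

The source may hold more compounds than are shown below. What is called first, only, known or untested is meant among the compounds shown, and "the series" means these compounds.

Measured so far in a functional assay on KB cells (Homo sapiens) for cytotoxicity, read by MTT assay, with a stated time of 72 h; a lower number here means that less compound is needed, a higher number that more compound is needed for the effect:
compound 1 `COc1ccc(/C=C2\C(=O)N(c3c(Cl)cccc3Cl)c3ccccc32)cc1OC` gives 10 ug/mL
compound 2 `O=C1/C(=C\c2cc3ccccc3nc2Cl)c2ccccc2N1c1c(Cl)cccc1Cl` gives 10 ug/mL
compound 3 `Cc1ccc2nc(Cl)c(/C=C3\C(=O)N(c4c(Cl)cccc4Cl)c4ccccc43)cc2c1` gives 100 ug/mL

Compound 1 stands level with compound 2 at the digits shown, the two together the lowest of the three numbers; compound 3 lies well above both.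

Compound 4 `COc1ccc(/C=C2\C(=O)N(c3c(Cl)cccc3Cl)c3ccccc32)cc1` differs from compound 1 by hydrogen in place of methoxy on an aromatic carbon. Among the compounds with values here, the only measured step, a 10-fold higher number from compound 2 to compound 3 (1.00 log units; beyond the scatter), concerns a methyl entering on a different part of the scaffold, so no measured step bears directly on the loss of a methoxy. The expectation for compound 4 is therefore a step of a 2.0-fold higher number from compound 1 to compound 4 (0.30 log units; within the scatter) in this assay, a small rise at most, with wide uncertainty. Compound 4 is estimated at 20 ug/mL, between 7 ug/mL and 60 ug/mL.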

Compound 4, concentration for half-maximal effect: > 100 ug/mL
Compound 4 ended at the assay's limit; the forecaster's own chance of this, stated with the estimate: 10%; at least 5.0-fold (0.69 log units) between middle value and limit.
By their numbers in this assay, from the lowest: compounds 1 and 2 (each within the scatter of the next); then compound 3.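

In this assay, within the data shown here, the change from methoxy to hydrogen on this aromatic carbon, meta to a large group, gives an at least 10-fold higher number from compound 1 to compound 4 (1.00 log units; beyond the scatter) and so moves the number beyond the scatter, which the earlier compounds could not show for this position. The methoxy that compound 4 keeps does not hold the number of compound 1 on its own. Compound 4 gives > 100 ug/mL which is a limit and not a number: the limit of > 100 ug/mL in this assay, at which 1 of the 4 values shown sits.

Going by these compounds, whether a hydroxyl, a fluorine or an ethoxy on this carbon would hold the number of compound 1 stays open. Also open, on these data alone, is how the remaining methoxy responds to the same change.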